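A few compounds are considered here, and "the series" means these few. Any claim that something is new, unique, unknown or untested is made for them only; others in the source may bear on it.

Measured compounds:

Compound 1, `CNc1nccc(N2CC[C@H](NC(=O)Nc3ccc(CN(C)C)c(C(F)(F)F)c3)C2)n1`, gives 40.1 nM.
Compound 2, `CNc1nccc(N2CC[C@H](NC(=O)Nc3ccc(Cl)c(C(F)(F)F)c3)C2)n1`, gives 10.1 nM.
Compound 3, `CNc1nccc(N2CC[C@H](NC(=O)Nc3ccc(CN4CCC4)c(C(F)(F)F)c3)C2)n1`, gives 99.9 nM.

These three share one core and differ only in the group carried on one aromatic carbon. In an assay on a protein complex for displacement of a labelled ligand from CDK8/Cyclin C (Homo sapiens), read by TR-FRET, with a stated time of 1 h (a lower number here means a stronger inhibitor, a higher number a weaker inhibitor), compound 3 stands with the highest number of the three; compound 1 lies nearest to it, and compound 2 lies furthest away.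

Compound 4, `CNc1nccc(N2CC[C@H](NC(=O)Nc3ccc(CN4CCCC4)c(C(F)(F)F)c3)C2)n1`, has not yet been measured. It differs from compound 3 by pyrrolidin-1-yl in place of azetidin-1-yl on a saturated chain carbon bound to an aromatic carbon. The step that bears most directly on this is the one within the same family of amine-bearing groups, a 2.5-fold higher number from compound 1 to compound 3 (0.40 log units; beyond the scatter), which went upward when the four-membered ring replaced the open dimethylamino group. The larger step of a 9.9-fold higher number from compound 2 to compound 3 (1.00 log units; beyond the scatter) involves a different kind of group and says less about a change within the ring. Widening the ring by one carbon is a small change of the same kind, so compound 4 is expected to stay close to compound 3, with a step of a 1.1-fold lower number from compound 3 to compound 4 (0.05 log units; within the scatter) at most and no firm direction.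

Compound 4 is therefore estimated at 90 nM, within the range from 35 nM to 230 nM.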

Compound 4, half-maximal inhibitory concentration in the CDK8/Cyclin C assay: 157 nM
For compound 4 the middle estimate is 1.7-fold (0.24 log units) below the measured one; measured number inside the range.
By their numbers in the CDK8/Cyclin C assay, from the lowest: compound 2; then compound 1; then compounds 3 and 4 (each within the scatter of the next).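

In the CDK8/Cyclin C assay the wider ring gives no readable change at this saturated chain carbon (a 1.6-fold higher number from compound 3 to compound 4 (0.20 log units; within the scatter)), so this read-out does not separate the two rings. Compound 4 still stands apart from the open-chain and chloro compounds, in the CDK8/Cyclin C assay (a 3.9-fold higher number from compound 1 to compound 4 (0.59 log units; beyond the scatter)) and (a 16-fold higher number from compound 2 to compound 4 (1.19 log units; beyond the scatter)), the larger gap being to chloro. The change does register in a physicochemical assay for solubility, measured as kinetic solubility (a lower number here means a less soluble compound, a higher number a more soluble compound), where compound 3 gives 84900 nM and compound 4 gives 37400 nM and the ring with the added carbon goes with the lower number: the measured solubility of compound 3, 84900 nM, and of compound 4, 37400 nM, a 2.3-fold lower number (0.36 log units; beyond the scatter)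

Still open, on these data alone, is whether a piperidin-1-yl or morpholin-4-yl group on the same saturated chain carbon would follow compound 4 in both assays. The compounds shown also cannot tell whether the distance from chloro follows the amine nitrogen or the added carbon, a question that a plain methyl or methoxy group on that aromatic carbon would address.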